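The source may hold more compounds than are shown below. What is called first, only, known or untested is meant among the compounds shown, and "the series" means these compounds.

Working notes on the series. Compound 2 `Cc1cc(C)c(CN2CCc3c(Cl)cc([C@@H](CO)[C@@H]4CCCO4)c(Cl)c3C2=O)c(=O)[nH]1` gives in an assay for inhibition of histone-lysine N-methyltransferase EZH2 variant Y641N (Homo sapiens), read by scintillation counting, with a stated time of 60 min, in the presence of a further agent that is not named here (a higher number here means a weaker inhibitor, a lower number a stronger inhibitor), 135 nM, the only number shown for it; a further entry for compound 2 in this assay carries no single number. Compound 1 `CCOC(c1cc(Cl)c2c(c1Cl)C(=O)N(Cc1c(C)cc(C)[nH]c1=O)CC2)C1CS(=O)(=O)C1` stands in this assay at 460 nM; 2.9 nM (2 entries), and the spread in the several entries of compound 1 in this assay, 460 nM; 2.9 nM (2 entries) shows how far two entries for one compound can lie apart here. Compound 3 `Cc1cc(C)c(CN2CCc3c(Cl)cc([C@@H](C)CO)c(Cl)c3C2=O)c(=O)[nH]1` has not been measured in this assay. The change from compound 2 to compound 3 is a group of 4 heavy atoms (3 carbon, 1 oxygen; no ring) in place of a group of 8 heavy atoms (6 carbon, 2 oxygen; one five-membered non-aromatic ring with 1 hetero atom), on an aromatic carbon. For the measured compounds named here, with no measured step of this kind, the expected step from compound 2 to compound 3 is a 3.0-fold higher number from compound 2 to compound 3 (0.47 log units; beyond the scatter), toward weaker inhibition, somewhat beyond the scatter. Compound 3 is estimated at 400 nM, within 100 nM to 1600 nM.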

Compound 3, inhibition constant in the histone-lysine N-methyltransferase EZH2 assay: 260 nM
The estimate for compound 3 lay 1.5-fold (0.19 log units) above the measured number; measured number inside the range.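

In the histone-lysine N-methyltransferase EZH2 assay, setting 1-(hydroxymethyl)ethyl on this aromatic carbon in place of the group with the five-membered non-aromatic ring gives a 1.9-fold higher number from compound 2 to compound 3 (0.28 log units; within the scatter). At this position, then, the ring and the second defined stereocentre can go without a shift in inhibition that exceeds the scatter. In a physicochemical assay for lipophilicity, at pH 7.4 (a higher number here means a more lipophilic compound, a lower number a more polar compound), the same change does register, from compound 2 at 2.1 to compound 3 at 2.5, with a more lipophilic compound despite the smaller group: the measured distribution coefficient of compound 2, 2.1, and of compound 3, 2.5, a number 0.40 log units higher (beyond the scatter)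

On these data alone, whether an amine or a carboxylic acid on this carbon would also leave inhibition within the scatter stays open. How finely a step of this size can be read in the histone-lysine N-methyltransferase EZH2 assay also stays open, given the entries for a single compound: the several entries of compound 1 in the histone-lysine N-methyltransferase EZH2 assay, 460 nM; 2.9 nM (2 entries)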